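Trifluoroacetyl in Place of a Carboxypyridinyl Arm

This account rests on a few compounds, and the source may have more. Where it says the series, first, only, none or still open, it means among the compounds named here.

Among the compounds with values here, compound 1, `O=C(O)c1ccc(-c2cnc(C(=O)CCc3ccc(-c4ccccc4)cc3)o2)cn1`, is one of two compounds measured in an assay for inhibition of Fatty-acid amide hydrolase 1 (Rattus norvegicus); a lower number here means a stronger inhibitor, a higher number a weaker inhibitor. In this assay compound 1 gives 44 nM, the higher of the two numbers, so it is the weaker of the pair. Within the data shown here, compound 2, `COC(=O)c1cnc(C(=O)CCc2ccc(COc3ccccc3)cc2)o1`, gives 1.6 nM in this assay; the two compounds differ in more than one place, so their values show only that compound 2 sits well below compound 1, beyond the usual scatter. Compound 3, `O=C(CCc1ccc(-c2ccccc2)cc1)c1ncc(C(=O)C(F)(F)F)o1`, is not yet measured. It differs from compound 1 by (trifluoromethyl)carbonyl in place of 6-carboxypyridin-3-yl on an aromatic carbon. Among the measured compounds shown here, no single-change step between measured compounds is available to anchor this change. A step of moderate size toward a lower number is expected, with the estimated step from compound 1 to compound 3 being a 7.3-fold lower number from compound 1 to compound 3 (0.87 log units; beyond the scatter). The expected value for compound 3 in this assay is 6 nM, with a range from 1.5 nM to 30 nM.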

Compound 3, inhibition constant: 8 nM
Estimate against measurement, compound 3: 1.3-fold (0.12 log units) below; the range from low to high includes it.
By their numbers in this assay, from the lowest: compound 2; then compound 3; then compound 1.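

Within the data shown here, the change from compound 1 to compound 3 gives the first single-change reading at this position: in this assay the exchange of 6-carboxypyridin-3-yl for (trifluoromethyl)carbonyl on this aromatic carbon next to the ring oxygen produces a 5.5-fold lower number from compound 1 to compound 3 (0.74 log units; beyond the scatter) with the rest of the molecule unchanged. At this position, then, the six-membered aromatic ring and the hydrogen-bond donor of the departing group are not required for a number in this range. No measurement that bears on the reason for this step is available.

Because the ring, the carboxylic acid and the fluorines all change in one step, the compounds shown do not separate their contributions. Open too, going by these compounds, is how a plain acetyl group, a nitrile or an unsubstituted pyridin-3-yl would read on this carbon.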